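The source may hold more compounds than are shown below. What is called first, only, known or untested is meant among the compounds shown, and "the series" means these compounds.

In an ADME assay on HUVEC cells (Homo sapiens) for cytotoxicity, read by MTT assay, with a stated time of 72 h (a lower number here means a stronger inhibitor, a higher number a weaker inhibitor), compound 1 `C=C1CC[C@H]2C(C)(C)CCC[C@]2(C)[C@H]1CCC(C)CC(=O)OC` gives > 200000 nM, which is a limit and not a number. Compound 2 `CC(CC[C@H]1/C(=C/c2ccc([N+](=O)[O-])cc2)CC[C@H]2C(C)(C)CCC[C@]12C)CC(=O)O` gives 194000 nM. Compound 3 `COc1ccc(/C=C2\CC[C@H]3C(C)(C)CCC[C@]3(C)[C@H]2CCC(C)CC(=O)O)cc1OC` gives > 200000 nM, also a limit and not a number, so its position is known only as a limit. The series sits against (the limit of > 200000 nM in this assay, at which 2 of the 3 values shown sit).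

Compound 4 `CC(CC[C@H]1/C(=C/c2ccc(I)cc2)CC[C@H]2C(C)(C)CCC[C@]12C)CC(=O)O` is next, and the change is 4-iodophenyl in place of 3,4-dimethoxyphenyl on a double-bonded chain carbon bound to a double-bonded ring carbon.

Within the data shown here, one measured step bears on this place: an at least 1.0-fold higher number from compound 2 to compound 3 (0.01 log units; that floor lies within the scatter). It exchanges 4-nitrophenyl for 3,4-dimethoxyphenyl at the same carbon. Among the measured compounds shown here, with that step as the only guide, no change beyond the scatter is expected in this assay, and no direction can be assigned. The expected step is an at least 1.1-fold lower number from compound 3 to compound 4 (0.07 log units; that floor lies within the scatter). For compound 4 the estimated value is 170000 nM, with an expected range of 90000 nM to 260000 nM.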

Compound 4, half-maximal inhibitory concentration: 100000 nM
Beside the measured number, compound 4's estimate is 1.7-fold (0.23 log units) above it, and the stated range covers the measured number.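

The exchange of 3,4-dimethoxyphenyl for 4-iodophenyl on a double-bonded chain carbon bound to a double-bonded ring carbon gives an at least 2.0-fold lower number from compound 3 to compound 4 (0.30 log units; that floor lies within the scatter). As far as these compounds go, that step is only a floor, and its full size stays unknown because one end of it rests on a limit: the limit of > 200000 nM in this assay, at which 2 of the 4 values shown sit. Iodo in place of nitro on an aromatic carbon gives a 1.9-fold lower number from compound 2 to compound 4 (0.29 log units; within the scatter), so these two groups are not separated in this assay.

From the compounds shown here alone, it remains open whether any group at this place can move the number beyond the scatter. An amine on an aromatic carbon, or a pyridine ring in place of the phenyl ring, would test this in this assay.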